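A few compounds are considered here, and "the series" means these few. Any claim that something is new, unique, unknown or untested is made for them only; others in the source may bear on it.

Measured so far in a functional assay on HeLa cells (Homo sapiens) for cytotoxicity, read by CCK-8 assay; a higher number here means a weaker inhibitor, a lower number a stronger inhibitor:
- compound 1 `Oc1ccccc1-c1cc(-c2ccco2)cc(-c2ccccc2O)n1`; in this assay compound 1 gives > 50000 nM, which is a limit of the assay and not a number.
- compound 2 `Oc1ccccc1-c1cc(-c2ccoc2)cc(-c2ccccc2O)n1`; in this assay compound 2 gives > 50000 nM, again a limit of the assay and not a number.

Compound 2 therefore stands at the upper limit of this assay, with no number behind it. The one measured step, a step that the two limits leave unreadable from compound 1 to compound 2, cannot be sized, since the limit of > 50000 nM in this assay, at which 2 of the 2 values shown sit, holds both ends of it; all that is shown is that exchanging one furan attachment for the other leaves the compound at the limit.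

Compound 3 `Oc1ccccc1-c1cc(-c2ccccn2)cc(-c2ccccc2O)n1` differs from compound 2 by pyridin-2-yl in place of furan-3-yl on an aromatic carbon. Among the compounds with values here, no measured step with a readable size bears on this change; the single step available only shows that a five-membered heteroaryl at this position gives no measurable inhibition either way. The expected outcome is that compound 3 likewise reports only a limit in this assay. For compound 3 the estimate in this assay is 60000 nM, within 20000 nM to 200000 nM. The expected step that the limit leaves unreadable from compound 2 to compound 3 is none beyond the scatter.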

Compound 3, half-maximal inhibitory concentration: > 50000 nM
Compound 3 ended at the assay's limit; the forecaster's own chance of this, stated with the estimate: 80%; the middle value is on the limit's open side.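

The steps from compound 3 to compound 1 and compound 2 cannot be read in this assay, because all three compounds stand at one limit of the assay, which is not a number: the limit of > 50000 nM in this assay, at which 3 of the 3 values shown sit.

The compounds shown leave open whether furan-2-yl, furan-3-yl and pyridin-2-yl differ at all in this assay.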